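Compound 4: one methoxy fewer, what follows?

A few compounds are considered here, and "the series" means these few. Any claim that something is new, unique, unknown or untested is made for them only; others in the source may bear on it.

Measured in a functional assay on HCT-116 cells (Homo sapiens) for inhibition, read by sulforhodamine B assay, with a stated time of 48 h, tested at 50 uM; on this read-out higher numbers stand for more inhibition of growth at the one concentration tested and lower numbers for less inhibition of growth:
compound 1 `COc1cc(/C=C/C(=O)/C=C/c2cccc3ccccc23)ccc1OCc1cn(CCCOc2cc(=O)oc3ccccc23)nn1`: 66%
compound 2 `COc1cccc(/C=C/C(=O)/C=C/c2ccc(OCc3cn(CCCCCOc4cc(=O)oc5ccccc45)nn3)c(OC)c2)c1`: 36%
compound 3 `COc1cccc(/C=C/C(=O)/C=C/c2ccc(OCc3cn(CCCOc4cc(=O)oc5ccccc45)nn3)c(OC)c2)c1`: 55%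

Of these three, compound 2 stands lowest at 36%, clearly under both of the others. The nearest is compound 3 at 55%, and the furthest is compound 1 at 66%.

The next compound, compound 4 `COc1cc(/C=C/C(=O)/C=C/c2ccccc2)ccc1OCc1cn(CCCCCOc2cc(=O)oc3ccccc23)nn1`, keeps the chain of compound 2 and alters the far aromatic end: hydrogen in place of methoxy on an aromatic carbon. In words, hydrogen stands in place of methoxy on an aromatic carbon, so 3-methoxyphenyl becomes phenyl.

Within the data shown here, only one measured step touches that end of the molecule. This is a number 11 percentage points lower from compound 1 to compound 3 (beyond the scatter), where 3-methoxyphenyl replaces naphthalen-1-yl. It was modest, and it was measured on the chain of compound 3, not on that of compound 2. Among the measured compounds shown here, no measured step removes a methoxy group outright, so the direction of the change is poorly supported.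

A small step at most is therefore expected in this assay, probably no larger than the modest step above and likely within the scatter. The expected change is a number 2 percentage points higher from compound 2 to compound 4 (within the scatter). For compound 4 the estimated value is 38%, with an expected range of 24% to 54%.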

Compound 4, percent growth inhibition at one concentration: 24%
Estimate against measurement, compound 4: 14 percentage points above; the measured number falls inside the stated range.
By their numbers in this assay, from the lowest: compound 4; then compound 2; then compound 3; then compound 1.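

In this assay, the loss of the methoxy group gives a number 12 percentage points lower from compound 2 to compound 4 (beyond the scatter), so this group on the far aromatic ring is not a silent passenger on the chain of compound 2, and 3-methoxyphenyl reads higher there than plain phenyl. Until now this end of the molecule had been seen only through an exchange of one aromatic group for another, on the chain of compound 3; here a single substituent is removed, and the number also falls, showing that even this small change at the far end registers beyond the scatter. No measurement at hand explains why the methoxy group matters here.

The compounds shown leave open whether removing the methoxy group would cost a similar amount on the chain of compound 3, or on a compound carrying naphthalen-1-yl. They also leave open how a hydroxy group, a fluorine atom or a dimethylamino group on that same aromatic carbon would read in this assay, and so whether methoxy itself is needed or any group there would serve.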